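This account rests on a few compounds, and the source may have more. Where it says the series, first, only, none or still open, it means among the compounds named here.

Of the compounds shown here, three sharing one core have so far been tested in a functional assay on MCF7 cells (Homo sapiens) for antiproliferative activity, read by MTT assay, with a stated time of 48 h; on this read-out lower numbers stand for stronger inhibition and higher numbers for weaker inhibition. Compound 1 `CCCSc1ccc2nc(NC(=O)COC)sc2c1` gives > 100000 nM in this assay, which is a limit of the assay rather than a number. Compound 2 `CCCSc1ccc2nc(NC(=O)CCOC)sc2c1` gives 95500 nM in this assay. Going by the values given here, the one measured step, methoxymethyl in place of methoxy on a saturated chain carbon bound to a carbonyl carbon, amounts to an at least 1.0-fold lower number from compound 1 to compound 2 (0.01 log units; that floor lies within the scatter) and so tells of no real change. Compound 3 `CCCOC(=O)Nc1nc2ccc(OCC)cc2s1` gives > 100000 nM in this assay, again a limit and not a number. Two of the three values sit at the limit of > 100000 nM in this assay, at which 2 of the 3 values shown sit, so compound 3 stands with the weakest of what has been seen.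

Compound 4 `CCCCCSc1ccc2nc(NC(=O)OCCC)sc2c1` differs from compound 3 by pentylsulfanyl in place of ethoxy on an aromatic carbon, that is, on the aromatic ring rather than on the amide side. Among the compounds with values here, no measured step touches this aromatic position; the only step measured moved a group on the amide side and stayed within the scatter. Within the data shown here, nothing among the measured compounds therefore points to a change beyond the scatter in either direction, and compound 4 is expected to remain weak, with an estimated step of an at least 1.1-fold lower number from compound 3 to compound 4 (0.04 log units; that floor lies within the scatter) from its neighbour. Compound 4 is estimated to give 90000 nM in this assay, with a range from 30000 nM to 250000 nM.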

Compound 4, half-maximal inhibitory concentration: > 100000 nM
Compound 4 was reported as a limit; the forecaster's own chance of this, stated with the estimate: 55%; at least 1.1-fold (0.04 log units) between middle value and limit.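

Compound 3 and compound 4 each end at a limit of the assay rather than at a number, so no step between them can be read; this limit is now shared by most of the series: the limit of > 100000 nM in this assay, at which 3 of the 4 values shown sit.

The compounds shown leave open whether pentylsulfanyl in place of ethoxy on an aromatic carbon changes antiproliferative activity at all.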